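Pyridin-4-yl in Place of Methyl: An Expected Shift

The source may report more compounds than this note shows. Statements on the series, on what has been measured and on what is new or still open speak of the compounds shown alone.

compound 1: `Cc1ccc(C(=O)Nc2ccc(C#N)cc2)c(O)c1`, 2420 nM
compound 2: `O=C(Nc1ccc(Br)c(Cl)c1)c1cc(F)ccc1O`, 600 nM

In a functional assay on HL-60 cells (Homo sapiens) for cytotoxicity, read by luminescence and CellTiter-Glo, with a stated time of 3 days (a lower number here means a stronger inhibitor, a higher number a weaker inhibitor), compound 1 gives 2420 nM, the highest of the two numbers shown; compound 2 gives 600 nM, a lower number that lies beyond the usual scatter. Compound 3, `N#Cc1ccc(NC(=O)c2ccc(-c3ccncc3)cc2O)cc1`, has not yet been measured in this assay. It differs from compound 1 in one place: pyridin-4-yl in place of methyl on an aromatic carbon. Among the compounds with values here, no measured pair shows this change, so its effect is unknown. A modest step toward a lower number is expected, a 1.6-fold lower number from compound 1 to compound 3 (0.21 log units; within the scatter). Compound 3 is therefore estimated at 1500 nM, with a likely range from 400 nM to 6000 nM.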

Compound 3, half-maximal inhibitory concentration: 7090 nM
Beside the measured number, compound 3's estimate is 4.7-fold (0.67 log units) below it, and the stated range ends below it.
By their numbers in this assay, from the lowest: compound 2; then compound 1; then compound 3.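

Putting pyridin-4-yl in place of methyl, at the carbon para to a large group and meta to a hydroxy group, gives a 2.9-fold higher number from compound 1 to compound 3 (0.47 log units; beyond the scatter) in this assay. At this position, then, the larger aromatic ring gives weaker inhibition, not stronger, although the step is modest. Nothing shown here accounts for this rise.

Still open, as far as these compounds go, is whether the ring nitrogen or the added ring as a whole drives the rise; a phenyl group at this position would separate the two. From the compounds shown here alone, how an amine or a carboxylic acid would behave here also remains unknown.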